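The source may report more compounds than this note shows. Statements on the series, on what has been measured and on what is new or still open speak of the compounds shown alone.

Compound 3 `CCOc1c(Br)cc(/C=C2\CCC/C(=C\c3cccc([N+](=O)[O-])c3)C2=O)cc1OC` gives 10.8 ug/mL in a functional assay on SK-N-MC cells (Homo sapiens) for cytotoxicity, read by MTT assay (a higher number here means a weaker inhibitor, a lower number a stronger inhibitor), the second highest of the three numbers recorded. Compound 2 `COc1cc(/C=C2\CCC/C(=C\c3cccc([N+](=O)[O-])c3)C2=O)cc(Br)c1OC` gives 16.7 ug/mL, and the step of a 1.5-fold lower number from compound 2 to compound 3 (0.19 log units; within the scatter) lies within the scatter. Among the compounds with values here, compound 1 `CCCOc1c(Br)cc(/C=C2\CCC/C(=C\c3ccccc3[N+](=O)[O-])C2=O)cc1OC` gives 3.5 ug/mL, a number beyond the scatter from compound 3, but compound 1 differs from compound 3 in two places, so no single step links them. Compound 4 `CCCOc1c(Br)cc(/C=C2\CCC/C(=C\c3cccc([N+](=O)[O-])c3)C2=O)cc1OC` differs from compound 3 by methyl in place of hydrogen on a saturated chain carbon, two bonds along the chain from an oxygen on an aromatic ring. Within the data shown here, the only measured step that bears on this lengthening of the chain, from methoxy to ethoxy, stayed within the scatter. Compound 4 is therefore expected to show no step beyond the scatter in this assay, a 1.1-fold lower number from compound 3 to compound 4 (0.06 log units; within the scatter). The expected value for compound 4 is 9.5 ug/mL, with a range from 4.5 ug/mL to 19 ug/mL.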

Compound 4, half-maximal inhibitory concentration: 1.51 ug/mL
Estimate against measurement, compound 4: 6.3-fold (0.80 log units) above; measured number below the stated range.
By their numbers in this assay, from the lowest: compound 4; then compound 1; then compounds 3 and 2 (each within the scatter of the next).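

In this assay, the chain on the oxygen turns out to matter once it reaches propoxy: ethoxy to propoxy gives a 7.2-fold lower number from compound 3 to compound 4 (0.85 log units; beyond the scatter), although methoxy to ethoxy had stayed within the scatter, and methoxy to propoxy overall gives an 11-fold lower number from compound 2 to compound 4 (1.04 log units; beyond the scatter). With propoxy held, 3-nitrophenyl in place of 2-nitrophenyl gives a 2.3-fold lower number from compound 1 to compound 4 (0.37 log units; beyond the scatter), so the nitrophenyl side also bears on the number. No evidence on the cause of these steps is at hand. On these data alone, whether a longer chain such as butoxy lowers the number further remains open, as does whether an amine in place of the nitro group would keep it.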